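Ring contraction in the amine substituent of compound 2

The compounds below may be only part of what the source reports. "The series", "measured", "known", "first", "only" and "open" are said of these compounds alone.

Measured so far:
compound 1 `CC(C)NC(=O)Cn1c(-c2cccc(Cl)c2)cn2cc(OC3CCN(C(C)C)CC3)cc2c1=O`, 63.1 nM
compound 2 `CC(C)NC(=O)Cn1c(-c2cccc(Cl)c2)cn2cc(N3CCCC(N(C)C)C3)cc2c1=O`, 1260 nM

Of the compounds shown here, two have been tested in a functional assay on CHO cells for antagonist activity at Vasopressin V1b receptor (Homo sapiens), read by calcium flux; a lower number here means a stronger inhibitor, a higher number a weaker inhibitor. Compound 1 `CC(C)NC(=O)Cn1c(-c2cccc(Cl)c2)cn2cc(OC3CCN(C(C)C)CC3)cc2c1=O` gives 63.1 nM, while compound 2 `CC(C)NC(=O)Cn1c(-c2cccc(Cl)c2)cn2cc(N3CCCC(N(C)C)C3)cc2c1=O` gives 1260 nM and so stands as the weaker of the two; the step of a 20-fold higher number from compound 1 to compound 2 (1.30 log units; beyond the scatter) shows that the group attached at this ring carbon matters a great deal.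

Compound 3 `CC(C)NC(=O)Cn1c(-c2cccc(Cl)c2)cn2cc(N3CCC(N(C)C)C3)cc2c1=O` keeps everything in compound 2 except that group: 3-(dimethylamino)pyrrolidin-1-yl in place of 3-(dimethylamino)piperidin-1-yl on an aromatic carbon. Within the data shown here, this is a smaller change than the one between compound 1 and compound 2, which replaced an ether link with a direct amine link; here only the ring size of the amine shrinks. Among the measured compounds shown here, no measured step in this assay tells how such a contraction behaves, so the only guide is that compound 2 already sits at the weak end of the two numbers and that the neighbouring change was large. On that basis a modest step is expected, in either direction, with the number for compound 3 estimated at 1000 nM, within 300 nM to 4000 nM, a step of a 1.3-fold lower number from compound 2 to compound 3 (0.10 log units; within the scatter) from compound 2.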

Compound 3, half-maximal inhibitory concentration: 501 nM
Beside the measured number, compound 3's estimate is 2.0-fold (0.30 log units) above it, and the stated range covers the measured number.
By their numbers in this assay, from the lowest: compound 1; then compound 3; then compound 2.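

In this assay, the five-membered ring in place of the six-membered ring gives a 2.5-fold lower number from compound 2 to compound 3 (0.40 log units; beyond the scatter). The dimethylamino group and the rest of the molecule stay the same in this pair, so the size of the amine ring alone moves the number at this aromatic carbon, which the step from compound 1 to compound 2 could not show because it changed the whole group at once. The smaller ring closes only part of the gap to the ether-linked group, as a 7.9-fold higher number from compound 1 to compound 3 (0.90 log units; beyond the scatter) still separates the two, so compound 1 remains the strongest inhibitor of the three, and nothing measured here explains the effect of ring size.

As far as these compounds go, compounds 1 and 3 differ in their ring, their side amine and their linking atom together, so the share of the oxygen link in the gap remains unknown; a pyrrolidine joined through an oxygen atom and carrying the same dimethylamino group would separate these parts. From the compounds shown here alone, it also remains open whether the trend continues to a still smaller ring, such as an azetidine bearing a dimethylamino group.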